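This account rests on a few compounds, and the source may have more. Where it says the series, first, only, none or still open, it means among the compounds named here.

Measured so far:
compound 1 `CCCCS(=O)(=O)Nc1cc(-c2ccc3c(c2)N(CCCn2cccn2)C(=O)CO3)cnc1OC` — 37900 nM
compound 2 `COc1ncc(-c2ccc3c(c2)N=C(N2CCN(CCCO)CC2)CO3)cc1NS(=O)(=O)c1ccc(F)cc1F` — 4780 nM

In a functional assay on MDA-MB-231 cells (Homo sapiens) for antiproliferative activity, read by sulforhodamine B assay, with a stated time of 72 h (on this read-out lower numbers stand for stronger inhibition and higher numbers for weaker inhibition), compound 2 gives 4780 nM, the lower of the two numbers recorded; compound 1 gives 37900 nM, and that gap lies beyond the scatter. Compound 3 `CCOC(=O)CN1CCN(C2=Nc3cc(-c4cnc(OC)c(NS(=O)(=O)c5ccc(F)cc5F)c4)ccc3OC2)CC1` is not yet measured. It differs from compound 2 by ethoxycarbonyl in place of 2-hydroxyethyl on a saturated chain carbon bound to an amine nitrogen in a ring, the alteration sitting on a saturated chain carbon bound to an amine nitrogen in a ring. Among the measured compounds shown here, no step between measured compounds isolates such a change, so no direction can be read from the data; a step within the scatter is expected. Compound 3 is estimated at 5000 nM, range 1500 nM to 16000 nM, implying an expected step of a 1.0-fold higher number from compound 2 to compound 3 (0.02 log units; within the scatter).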

Compound 3, half-maximal inhibitory concentration: 17200 nM
The estimate for compound 3 lay 3.4-fold (0.54 log units) below the measured number; measured number above the stated range.
By their numbers in this assay, from the lowest: compound 2; then compound 3; then compound 1.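

On a saturated chain carbon bound to an amine nitrogen in a ring, ethoxycarbonyl in place of 2-hydroxyethyl gives a 3.6-fold higher number from compound 2 to compound 3 (0.56 log units; beyond the scatter) in this assay, so this place in the series is not indifferent to the group it carries. Of the two groups, 2-hydroxyethyl gives the lower number. No measurement available explains the step.

As far as these compounds go, it remains open whether the rise comes with the arrival of ethoxycarbonyl or the departure of 2-hydroxyethyl. A carboxylic acid, an amine or a longer hydroxyalkyl chain at this place would help separate the two.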